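The compounds below may be only part of what the source reports. "The series", "measured", "known", "first", "only" and "open" are said of these compounds alone.

Measured so far:
Compound 1 `CCOC(=O)[C@@H](N)CCC(=O)NCCSC(=O)c1ccccc1`: 331000 nM
Compound 2 `CCCOC(=O)[C@@H](N)CCC(=O)NCCSC(C)=O`: 548000 nM

In an ADME assay on HaCaT cells (Homo sapiens) for cytotoxicity, read by MTT assay, with a stated time of 48 h (a higher number here means that more compound is needed for the effect, a lower number that less compound is needed), compound 2 gives 548000 nM, which lies within the usual scatter of compound 1 at 331000 nM. The next molecule, compound 3 `CCOC(=O)[C@@H](N)CCC(=O)NCCSC(C)=O`, differs from compound 2 by one small edit: hydrogen in place of methyl on a saturated chain carbon, two bonds along the chain from an oxygen next to a carbonyl group. Hydrogen stands in place of methyl on a saturated chain carbon, two bonds along the chain from an oxygen next to a carbonyl group, turning propoxy into ethoxy. Among the compounds with values here, no measured pair shows this change alone, so in this assay the expected 1.1-fold lower number from compound 2 to compound 3 (0.06 log units; within the scatter) does not go beyond the scatter. For compound 3 the estimated value is 480000 nM, with an expected range from 230000 nM to 950000 nM.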

Compound 3, half-maximal effective concentration: 1730000 nM
Compound 3: middle estimate off by 3.6-fold (0.56 log units), on the low side; measured number outside the range, above it.
By their numbers in this assay, from the lowest: compounds 1 and 2 (each within the scatter of the next); then compound 3.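

Shortening propoxy to ethoxy gives a 3.2-fold higher number from compound 2 to compound 3 (0.50 log units; beyond the scatter) in this assay and so shows that hydrogen in place of methyl at this saturated chain carbon can shift the number beyond the scatter. Methyl in place of phenyl on a carbonyl carbon gives a 5.2-fold higher number from compound 1 to compound 3 (0.72 log units; beyond the scatter) as a second step beyond the scatter, at a different place in the molecule. Nothing available explains either step.

A shorter methoxy or a longer butoxy group would test whether the number follows chain length. A cyclohexyl or pyridyl group on the carbonyl carbon would show whether phenyl behaves differently from other rings.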